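Swapping the amide substituent in a paw-edema series

This account rests on a few compounds, and the source may have more. Where it says the series, first, only, none or still open, it means among the compounds named here.

Measured compounds:
- compound 1, `CCOC(=O)c1c(O)c2cccnc2n(-c2ccccc2)c1=O`: 23.5%
- compound 2, `CNC(=O)c1c(O)c2cccnc2n(-c2ccccc2)c1=O`: 9.6%
- compound 3, `O=C(Nc1cccc(Cl)c1)c1c(O)c2cccnc2n(-c2ccccc2)c1=O`: 7.6%

All three share a core and were tested in a functional assay on the whole organism for inhibition, with Rattus norvegicus as the target, read by paw edema, at a dose of 100 mg/kg by the oral route; a higher number here means more inhibition at the dose given (going by the name of the read-out), a lower number less inhibition. Among them compound 3 gives the smallest number, yet its gap to compound 2 is within the scatter, so the two cannot be told apart; only compound 1 stands clearly apart, as the step of a number 15.9 percentage points lower from compound 1 to compound 3 (beyond the scatter) shows. The step of a number 2 percentage points lower from compound 2 to compound 3 (within the scatter) tells that exchanging the group on the amide-type nitrogen left the read-out essentially unchanged.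

Compound 4, `COc1ccc(NC(=O)c2c(O)c3cccnc3n(-c3ccccc3)c2=O)cn1`, carries the change (6-methoxypyridin-3-yl in place of 3-chlorophenyl on an amide-type nitrogen). It is again an exchange of the group on the amide-type nitrogen, the kind of change that in the step of a number 2 percentage points lower from compound 2 to compound 3 (within the scatter) stayed within the scatter. Within the data shown here, no other measured step touches this position, so on the present evidence nothing beyond the scatter is expected in this assay, in either direction: the expected step is a number 2.4 percentage points higher from compound 3 to compound 4 (within the scatter). Compound 4 is therefore estimated at 10%, with a likely range from 0% to 24%.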

Compound 4, a percentage reported as inhibition, in the whole organism at one dose (the size of the read-out at that dose, not a potency): 13.1%
Beside the measured number, compound 4's estimate is 3.1 percentage points below it; measured number inside the range.
By their numbers in this assay, from the lowest: compounds 3, 2 and 4 (each within the scatter of the next); then compound 1.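

Compound 4 adds a third kind of group on the amide-type nitrogen, and the change to 6-methoxypyridin-3-yl gives a number 5.5 percentage points higher from compound 3 to compound 4 (within the scatter) and a number 3.5 percentage points higher from compound 2 to compound 4 (within the scatter) in this assay, so even a ring with a hetero atom does not separate from the 3-chlorophenyl or methyl groups. The ethoxy compound still stands apart, with a number 10.4 percentage points lower from compound 1 to compound 4 (beyond the scatter) as the third amide step of this kind, so within these compounds the clear difference lies between ethoxy and the amino groups, not among the amino groups. Nothing available explains these numbers.

Still open, on these data alone, is whether a longer chain such as hexyl, or a phenyl ring carrying a carboxylic acid, on this nitrogen would move the number beyond the scatter. Also open, as far as these compounds go, is whether an ester other than ethyl, such as benzyl, would keep the higher number seen with compound 1 at 23.5% in this series.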